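This account rests on a few compounds, and the source may have more. Where it says the series, first, only, none or still open, it means among the compounds named here.

In a functional assay on SK-MEL-2 cells (Homo sapiens) for inhibition, with a stated time of 48 h (a lower number here means a stronger inhibitor of growth, a higher number a weaker inhibitor of growth), compound 1 `COc1ccccc1/C=C/C(=O)c1c(O)cc2occc2c1OC` returns only a limit of the assay, > 100000 nM. Two relatives give real numbers: compound 2 `COc1c(C(=O)/C=C/c2ccc(Cl)cc2)c(O)c(Br)c2occc12` reaches 4160 nM and compound 3 `C=CCc1c(O)c(C(=O)/C=C/c2ccccc2)c(OC)c2ccoc12` reaches 3040 nM, and these two lie within the usual scatter of each other. Compound 4 `C=CCc1c(O)c(C(=O)/C=C/c2ccc(Cl)cc2)c(OC)c2ccoc12` departs from compound 3 by one change, chloro in place of hydrogen on an aromatic carbon, turning phenyl into 4-chlorophenyl. Within the data shown here, no measured pair isolates this change. Compound 2 already carries a 4-chlorophenyl group and gives 4160 nM, so only a small shift is expected. The expected step of a 1.2-fold lower number from compound 3 to compound 4 (0.08 log units; within the scatter) is not estimated to go beyond the scatter. For compound 4 the estimate is 2500 nM, with an expected range of 900 nM to 7000 nM.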

Compound 4, concentration for 50% growth inhibition: 3970 nM
Compound 4: the middle estimate sits 1.6-fold (0.20 log units) below what was measured; the measured number falls inside the stated range.
By their numbers in this assay, from the lowest: compounds 3, 4 and 2 (each within the scatter of the next). At a limit, above all of these: compound 1.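

Among these compounds, at this place on the ring, para to a large group, chloro in place of hydrogen gives the first measured pair for this change, and the step stays within the scatter (a 1.3-fold higher number from compound 3 to compound 4 (0.12 log units; within the scatter)). Allyl in place of bromo on an aromatic carbon also stays within the scatter (a 1.0-fold lower number from compound 2 to compound 4 (0.02 log units; within the scatter)). Neither change separates these compounds in this assay, and nothing measured here speaks to why. On these data alone, whether an amine or a carboxylic acid at the chloro position would shift the number stays open. So does the effect of a longer chain in place of allyl.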